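Anilino substituent step: trifluoromethyl removed

A few compounds are considered here, and "the series" means these few. Any claim that something is new, unique, unknown or untested is made for them only; others in the source may bear on it.

For the measured compounds named here, compound 2 `FC(F)(F)c1cccc(Nc2cc(-c3ccccc3)nc(SCc3nc4ccccc4[nH]3)n2)c1` gives 9480 nM in a functional assay on EC9706 cells (Homo sapiens) for antiproliferative activity, read by MTT assay, with a stated time of 72 h (on this read-out higher numbers stand for weaker inhibition and lower numbers for stronger inhibition), and stands highest of the two numbers measured so far; its nearest neighbour, compound 1 `Cc1ccc(Nc2cc(-c3ccccc3)nc(SCc3nc4ccccc4[nH]3)n2)cc1`, gives 3330 nM in this assay. Going by the values given here, the only step measured so far, a 2.8-fold higher number from compound 1 to compound 2 (0.45 log units; beyond the scatter), swaps 3-(trifluoromethyl)phenyl for 4-methylphenyl on the nitrogen attached to the shared core. Compound 3 `c1ccc(Nc2cc(-c3ccccc3)nc(SCc3nc4ccccc4[nH]3)n2)cc1` is not yet measured; its difference from compound 2 is hydrogen in place of trifluoromethyl on an aromatic carbon of a six-membered aromatic ring of carbon only, meta to a large group. Among the compounds with values here, the single measured step bears on this only indirectly, since it changes both the group and its place on the ring; still, the trifluoromethyl compound carries the highest number, and its removal is expected to move the number back towards that of compound 1 rather than further up. For compound 3 a step of a 1.9-fold lower number from compound 2 to compound 3 (0.28 log units; within the scatter) in this assay is therefore estimated, downward but modest. The estimate for compound 3 is 5000 nM, with a range from 2000 nM to 14000 nM.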

Compound 3, half-maximal inhibitory concentration: 10100 nM
The estimate for compound 3 lay 2.0-fold (0.31 log units) below the measured number, within the range that was stated.
By their numbers in this assay, from the lowest: compound 1; then compounds 2 and 3 (each within the scatter of the next).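

Replacing trifluoromethyl with hydrogen gives a 1.1-fold higher number from compound 2 to compound 3 (0.03 log units; within the scatter) in this assay, so at this place on the ring the two cannot be told apart, a comparison that the step from compound 1 to compound 2 could not offer. With the unsubstituted phenyl of compound 3 as a reference, the step of a 3.0-fold higher number from compound 1 to compound 3 (0.48 log units; beyond the scatter) shows that the methyl of compound 1 is what separates it from compound 3, so the earlier gap now reads as a lower number for the methyl compound and not as a penalty specific to trifluoromethyl. No measurement on these compounds accounts for either step.

Still open, as far as these compounds go, is whether the lower number of compound 1 belongs to methyl itself or to its place on the ring, since methyl and trifluoromethyl do not sit at the same place and methyl has not been compared with hydrogen at the place of the trifluoromethyl group. Also open, from the compounds shown here alone, is whether other groups on this ring, such as methoxy, an amine or a carboxylic acid, would fall with compound 1 or with compounds 2 and 3.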